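Adding a Second Hydroxy to a Permeable Furan Core

The source may hold more compounds than are shown below. What is called first, only, known or untested is meant among the compounds shown, and "the series" means these compounds.

Measured compounds:
Compound 1, `Oc1ccc2cc(-c3ccc4cccc(O)c4n3)oc2c1`, 15.8 10^-6 cm/s
Compound 2, `Oc1cc(O)c2cc(-c3ccc4cccc(O)c4n3)oc2c1`, 13.3 10^-6 cm/s
Compound 3, `Oc1ccc2cc(-c3cc(I)c(O)c4ncccc34)oc2c1`, 16.6 10^-6 cm/s

In an ADME assay for permeability, using PAMPA, with a stated time of 10 h, tested at 100 ug/mL (on this read-out higher numbers stand for higher permeability and lower numbers for lower permeability), compound 1 gives 15.8 10^-6 cm/s. Compound 2 carries one more hydroxy on the core of compound 1, a change summarised as hydroxy in place of hydrogen on an aromatic carbon, and this gave a 1.2-fold lower number from compound 1 to compound 2 (0.07 log units; within the scatter). Compound 3 is built on a different core; how the core of compound 3 differs from the core of compound 1 is not broken down here. In this assay compound 3 gives 16.6 10^-6 cm/s, and its numbers and those of compound 1 and compound 2 all lie within the usual scatter of one another.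

Compound 4, `Oc1cc(O)c2cc(-c3cc(I)c(O)c4ncccc34)oc2c1`, has not yet been measured. It stands to compound 3 as compound 2 stands to compound 1: the change is hydroxy in place of hydrogen on an aromatic carbon, the same change at the same kind of place. Because the earlier step of a 1.2-fold lower number from compound 1 to compound 2 (0.07 log units; within the scatter) stayed within the scatter, the expected step from compound 3 to compound 4 is estimated as a 1.2-fold lower number from compound 3 to compound 4 (0.07 log units; within the scatter). Compound 4 is therefore expected to give about 14 10^-6 cm/s in this assay, estimated between 9 10^-6 cm/s and 22 10^-6 cm/s.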

Compound 4, apparent permeability: 0.8 10^-6 cm/s
For compound 4 the middle estimate is 18-fold (1.24 log units) above the measured one; measured number outside the range, below it.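

Putting hydroxy in place of hydrogen on an aromatic carbon of the core of compound 3 gave, in this assay, a 21-fold lower number from compound 3 to compound 4 (1.32 log units; beyond the scatter). The same change therefore did not carry from one core to the other with the same size, and the pair on the core of compound 1 was a poor guide to the pair on the core of compound 3: the same change on two cores in this assay, a 1.2-fold lower number (0.07 log units; within the scatter) from compound 1 to compound 2 and a 21-fold lower number (1.32 log units; beyond the scatter) from compound 3 to compound 4, 17-fold (1.24 log units) apart, beyond the scatter of two such steps. This shows that the core matters for this change in these two pairs, but it does not show which difference between the two cores is responsible, what causes the large step, or how the change would behave on any further core.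

The compounds shown leave open whether a methoxy or an amine in the same place on the core of compound 3 would bring a similar large step. Within the data shown here, they also leave open whether the step depends on the iodine atom that compound 3 and compound 4 carry, since no pair here tests it alone.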